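This account rests on a few compounds, and the source may have more. Where it says the series, first, only, none or still open, it means among the compounds named here.

Compound 3 `COc1ccc(-c2cnc(NC(=O)c3ccncc3)n2C)cc1` is the starting point here, and how much of it the cells tolerate was tested in a toxicity assay on THP-1 cells (Homo sapiens) for inhibition; a lower number here means that less compound is tolerated, a higher number that more compound is tolerated. In this assay compound 3 gives > 100000 nM, which is a limit of the assay rather than a measured number. Its two neighbours share this fate. Compound 1 `COc1ccc(-c2cnc(NC(=O)c3ccccc3OC)n2C)cc1` gives > 100000 nM in this assay, again a limit. Compound 2 `COc1ccc(-c2cnc(NC(=O)C3CCNCC3)n2C)cc1` gives > 100000 nM in this assay, also a limit. Because (the limit of > 100000 nM in this assay, at which 3 of the 3 values shown sit), none of the steps between them can be read: the step that the two limits leave unreadable from compound 1 to compound 2, the step that the two limits leave unreadable from compound 1 to compound 3 and the step that the two limits leave unreadable from compound 2 to compound 3 all remain of unknown size. Compound 4 `COc1ccc(-c2cnc(NC(=O)c3ccccc3Cl)n2C)cc1` has not yet been measured. It differs from compound 3 in one place: 2-chlorophenyl in place of pyridin-4-yl on a carbonyl carbon. Going by the values given here, with every measured compound sitting at the same limit, no measured step bears on this change in a readable way, so the step from compound 3 to compound 4 is expected to be a number no higher from compound 3 to compound 4 (the limit leaves the size open) in this assay, nothing that can be seen beyond the scatter. Compound 4 is therefore estimated to give 100000 nM in this assay, within a range from 30000 nM to 300000 nM, most probably again reported only as a limit.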

Compound 4, half-maximal cytotoxic concentration: > 50000 nM
Compound 4 was reported as a limit; the forecaster's own chance of this, stated with the estimate: 80%; the middle value is on the limit's open side.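

Compound 4 is reported only as a limit in this assay, like compound 1, compound 2 and compound 3, and none of the steps from these three to compound 4 can be read. The compounds shown leave open at what concentration any of them becomes half-maximally cytotoxic.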